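Chloro substitution on the phenyl of compound 3

The source may report more compounds than this note shows. Statements on the series, on what has been measured and on what is new or still open speak of the compounds shown alone.

In a functional assay on CHO cells for agonist activity at metabotropic glutamate receptor 2 (Homo sapiens), read by FLIPR (on this read-out higher numbers stand for an effect only at larger amounts of compound and lower numbers for an effect already at smaller amounts), compound 1 `Cn1c(CN2CCN(c3ccc(C(F)(F)F)cc3)CC2)nc2ccccc21` gives 6310 nM. Compound 2 `Cn1c(CN2CCN(c3ccccc3C(F)(F)F)CC2)nc2ccccc21` gives only a limit and no number, > 15800 nM; this is the limit of > 15800 nM in this assay, at which 1 of the 3 values shown sits. Compound 3 `Cn1c(CN2CCC(c3ccccc3)CC2)nc2ccccc21` gives 6310 nM, level with compound 1 within the scatter. Compound 4 `Cn1c(CN2CCC(c3ccc(Cl)cc3)CC2)nc2ccccc21` differs from compound 3 by chloro in place of hydrogen on an aromatic carbon. For the measured compounds named here, no step between measured compounds is available to size this change, so the expectation rests on compound 3 at 6310 nM alone: a small step, if any, toward lower concentration, not clearly beyond the scatter. Compound 4 is expected at 4000 nM, within 1500 nM to 12000 nM, which means an expected step of a 1.6-fold lower number from compound 3 to compound 4 (0.20 log units; within the scatter).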

Compound 4, half-maximal effective concentration: 5010 nM
For compound 4 the middle estimate is 1.3-fold (0.10 log units) below the measured one, and the stated range covers the measured number.
By their numbers in this assay, from the lowest: compounds 4, 1 and 3 (each within the scatter of the next). At a limit, above all of these: compound 2.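

In this assay, for the compounds shown here, replacing phenyl with 4-chlorophenyl gives a 1.3-fold lower number from compound 3 to compound 4 (0.10 log units; within the scatter), the first step that can be sized. Chloro on this aromatic carbon, para to a large group, therefore keeps compound 4 level with compound 3. Nothing measured here accounts for the size of this step.

Going by these compounds, whether a methoxy group, an amine or a carboxylic acid at this place would give a step beyond the scatter stays open. So does whether chloro elsewhere on this ring would match compound 4.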